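This account rests on a few compounds, and the source may have more. Where it says the series, first, only, none or still open, it means among the compounds named here.

Measured so far:
compound 1 `COc1ccc(C(=O)/C=C/c2cc(-c3cc(OC)c(OC)c(OC)c3)n[nH]2)cc1OC` — -98%
compound 2 `COc1cc(-c2cc(/C=C/C(=O)c3ccc(F)c(F)c3)[nH]n2)cc(OC)c1OC` — -21%

In a functional assay on SK-MEL-5 cells (Homo sapiens) for cytotoxicity, read by sulforhodamine B assay, with a stated time of 48 h, tested at 10 uM (on this read-out lower numbers stand for a stronger effect and higher numbers for a weaker effect at the one concentration tested), compound 1 stands lowest of the two numbers measured; compound 2 sits a number 77 percentage points higher from compound 1 to compound 2 (beyond the scatter). Compound 3 `COc1cc(C(=O)/C=C/c2cc(-c3cc(OC)c(OC)c(OC)c3)n[nH]2)cc(OC)c1OC` differs from compound 1 by methoxy in place of hydrogen on an aromatic carbon. Among the measured compounds shown here, no measured step concerns a methoxy entering an aromatic carbon; the only step known exchanges the whole aryl group on the carbonyl, so it does not bear on this change. For compound 3 no step beyond the scatter is expected, the estimate being a number 10 percentage points higher from compound 1 to compound 3 (within the scatter). Compound 3 is therefore expected at -88%, within -100% to -55%.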

Compound 3, a percentage reported as activity, at one concentration (the size of the read-out at that concentration, not a potency): -98%
Compound 3: the middle estimate sits 10 percentage points above what was measured, within the range that was stated.
By their numbers in this assay, from the lowest: compounds 1 and 3 (each within the scatter of the next); then compound 2.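

In this assay, methoxy in place of hydrogen on an aromatic carbon, ortho to a methoxy group, gives no change at the digits printed from compound 1 to compound 3 (within the scatter) for this change. This position therefore takes a methoxy with the read-out held within the scatter, which the earlier step on the whole aryl group (a number 77 percentage points higher from compound 1 to compound 2 (beyond the scatter)) left unaddressed. No measurement available here explains this result.

Open, on these data alone, is whether an amine, a hydroxyl or a longer ethoxy chain at this position would also hold the read-out. Also open, as far as these compounds go, is whether the methoxy would behave alike with a 3,4-difluorophenyl on the carbonyl.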